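This account rests on a few compounds, and the source may have more. Where it says the series, first, only, none or still open, it means among the compounds named here.

In an assay on isolated protein for displacement of a labelled ligand from Apoptosis regulator Bcl-2 (Homo sapiens), with a stated time of 15 min (a higher number here means a weaker inhibitor, a lower number a stronger inhibitor), compound 1 `CC1(C)CCC(CN2CCN(c3ccc(C(=O)NS(=O)(=O)c4ccc(NCC5CCOCC5)c([N+](=O)[O-])c4)c(Oc4cnc5[nH]ccc5c4)c3)CC2)=C(c2ccc(Cl)cc2C(F)(F)F)C1` gives 0.86 nM, compound 2 `CC1(C)CCC(CN2CCN(c3ccc(C(=O)NS(=O)(=O)c4ccc(NCC5CCOCC5)c([N+](=O)[O-])c4)c(Oc4cnc5[nH]ccc5c4)c3)CC2)=C(c2ccccc2C(F)(F)F)C1` gives 1.7 nM and compound 3 `CN(C)CCCNc1ccc(S(=O)(=O)NC(=O)c2ccc(N3CCN(CC4=C(c5ccc(C(F)(F)F)cc5)CC(C)(C)CC4)CC3)cc2Oc2cnc3[nH]ccc3c2)cc1[N+](=O)[O-]` gives 0.89 nM. Compound 3 thus stands second highest of the three numbers, with compound 1 nearest and compound 2 furthest, both gaps within the scatter. Compound 4 `CC(C)C(=O)N1CCC(CNc2ccc(S(=O)(=O)NC(=O)c3ccc(N4CCN(CC5=C(c6ccc(C(F)(F)F)cc6)CC(C)(C)CC5)CC4)cc3Oc3cnc4[nH]ccc4c3)cc2[N+](=O)[O-])CC1` differs from compound 3 by 1-(isopropylcarbonyl)piperidin-4-yl in place of 2-(dimethylamino)ethyl on a saturated chain carbon bound to a nitrogen on an aromatic ring. Within the data shown here, no measured step touches that part of the series; the only step known, a 2.0-fold higher number from compound 1 to compound 2 (0.30 log units; within the scatter), sits on another part of the structure and is itself within the scatter. With nothing pointing either way, the expected change in this assay is none beyond the scatter, a 1.3-fold higher number from compound 3 to compound 4 (0.13 log units; within the scatter). Compound 4 is therefore estimated at 1.2 nM, in the range 0.4 nM to 4 nM.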

Compound 4, half-maximal inhibitory concentration: 2.4 nM
Compound 4: the middle estimate sits 2.0-fold (0.30 log units) below what was measured; the measured number falls inside the stated range.
By their numbers in this assay, from the lowest: compounds 1, 3, 2 and 4 (each within the scatter of the next, the first and the last beyond it).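

In this assay, 1-(isopropylcarbonyl)piperidin-4-yl in place of 2-(dimethylamino)ethyl gives a 2.7-fold higher number from compound 3 to compound 4 (0.43 log units; beyond the scatter), so this position responds to the change, although the step is modest and compound 4 still gives 2.4 nM. Among these compounds, the change swaps the dimethylamino group for a ring and adds an isopropylcarbonyl group, and the single step cannot separate these two parts. Nothing available accounts for the step.

Open, on these data alone, is whether a free piperidin-4-yl, without the isopropylcarbonyl, would stand nearer compound 3 or compound 4. Also open, as far as these compounds go, is how a morpholine or a longer dimethylamino chain would read here.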